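From a Pyridine to an Acetylphenyl: A Cytotoxicity Check

The source may hold more compounds than are shown below. What is called first, only, known or untested is meant among the compounds shown, and "the series" means these compounds.

Compound 2 `CCOC(=O)CCCCCOc1cccc(CN(C(=O)c2ccc(-c3ccncc3)cc2)C(C)C)c1` carries a pyridin-4-yl group on an aromatic carbon of the shared core. In an ADME assay on Raji cells (Homo sapiens) for cytotoxicity, read by CellTiter-Glo and resazurin assay, with a stated time of 72 h (a lower number here means that less compound is needed, a higher number that more compound is needed for the effect), compound 2 gives > 26000 nM, which is a limit of the assay rather than a measured number. Its parent, compound 1 `CCOC(=O)CCCCCOc1cccc(CN(C(=O)c2ccccc2)C(C)C)c1`, lacks that group. In this assay compound 1 gives > 26000 nM, again a limit. The step that the two limits leave unreadable from compound 1 to compound 2 therefore cannot be read, because the limit of > 26000 nM in this assay, at which 2 of the 2 values shown sit, leaves both values at the same edge. The next compound, compound 3 `CCOC(=O)CCCCCOc1cccc(CN(C(=O)c2ccc(-c3cccc(C(C)=O)c3)cc2)C(C)C)c1`, differs from compound 2 in one place: 3-acetylphenyl in place of pyridin-4-yl on an aromatic carbon. Going by the values given here, no measured step bears on this exchange, as the only available step is unreadable. With both known values at the limit, the expectation is that compound 3 likewise stays there, so the estimated step that the limit leaves unreadable from compound 2 to compound 3 is none beyond the scatter. Compound 3 is accordingly expected to give about 30000 nM, between 15000 nM and 100000 nM.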

Compound 3, half-maximal effective concentration: > 26000 nM
Compound 3 was reported as a limit; the forecaster's own chance of this, stated with the estimate: 85%; the middle value lies beyond the limit too.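

No new step can be read from compound 1 to compound 3 or from compound 2 to compound 3, because all three compounds sit at the same edge of the scale: the limit of > 26000 nM in this assay, at which 3 of the 3 values shown sit.

The compounds shown leave open how far each one lies past that limit in this assay and whether pyridin-4-yl or 3-acetylphenyl changes the value at all.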